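A few compounds are considered here, and "the series" means these few. Any claim that something is new, unique, unknown or untested is made for them only; others in the source may bear on it.

Measured compounds:

Compound 1 `COc1ccc2nc(NC(=O)CNC(=O)c3nn(-c4ccccc4OC)c(=O)c4ccccc34)sc2c1`: 90 nM
Compound 2 `O=C(CSc1nc2c(c(=O)n1-c1ccccc1)SCC2)Nc1ccc(-c2ccoc2)cn1`: 1.5 nM
Compound 3 `O=C(CSc1nc2c(c(=O)n1-c1ccccc1)SCC2)Nc1ccc(-c2ccccc2)cc1`: 0.75 nM

These three compounds were tested in an assay on L cells for inhibition of Protein-serine O-palmitoleoyltransferase porcupine (Mus musculus), read by reporter gene assay, with a stated time of 24 h; a lower number here means that less compound is needed, a higher number that more compound is needed for the effect. Compound 1 gives 90 nM, the highest number of the set. Compound 2 gives 1.5 nM, and compound 3 gives 0.75 nM, the lowest number of the three; the gap between compound 3 and compound 2, however, is within the usual scatter, so the two cannot be ranked against each other, while compound 1 sits far beyond it.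

Compound 4 `CCOc1ccc(NC(=O)CSc2nc3c(c(=O)n2-c2ccccc2)SCC3)cc1` has not yet been measured in this assay. It shares the whole core of compound 3 and differs in one place: ethoxy in place of phenyl on an aromatic carbon. For the measured compounds named here, no measured pair shows this same change, so the direction has to be guessed from the structures alone. Compound 3 and compound 2 show that a ring in that region goes with a low number, and removing the phenyl ring in favour of a short ethoxy chain is expected to cost some potency, giving a moderate rise. For compound 4 the estimate is 4 nM, with a likely range from 1 nM to 20 nM, which corresponds to an expected step of a 5.3-fold higher number from compound 3 to compound 4 (0.73 log units; beyond the scatter).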

Compound 4, half-maximal effective concentration: 1000 nM
Beside the measured number, compound 4's estimate is 250-fold (2.40 log units) below it, outside the stated range (above it).
By their numbers in this assay, from the lowest: compounds 3 and 2 (each within the scatter of the next); then compound 1; then compound 4.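

In this assay putting ethoxy in place of phenyl on this aromatic carbon gives a 1300-fold higher number from compound 3 to compound 4 (3.12 log units; beyond the scatter) with the rest of the molecule unchanged. For the compounds shown here, this is the first measured pair that differs in one place, and it shows that this single change is enough for a large step, so what sits at this position matters greatly. No measurement shown explains why the change costs so much.

Going by these compounds, only one replacement at this position can be read, so it stays open whether the phenyl ring itself is needed or whether other groups could serve there. A cyclohexyl ring would test whether the ring must be aromatic, while a longer chain such as butoxy would test whether the shortness of ethoxy matters.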